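Halogen swap on a diaminoquinazoline nitrile series

This account rests on a few compounds, and the source may have more. Where it says the series, first, only, none or still open, it means among the compounds named here.

Measured so far:
compound 1, `CC(C)(C)Nc1c(C#N)c(F)c2c(N)nc(N)nc2c1Cl`, 2.1 ug/mL
compound 2, `CC(C)(C)Nc1c(C#N)c(F)c2c(N)nc(N)nc2c1F`, 2.4 ug/mL
compound 3, `CCN(CC)c1c(C#N)c(F)c2c(N)nc(N)nc2c1Cl`, 0.4 ug/mL

Of the compounds shown here, three have been tested in a functional assay on SK-OV-3 cells (Homo sapiens) for cytotoxicity, read by MTT assay; a lower number here means a stronger inhibitor, a higher number a weaker inhibitor. Compound 1 and compound 2 share a core and differ only in the change (fluoro in place of chloro on an aromatic carbon); that change made a 1.1-fold higher number from compound 1 to compound 2 (0.06 log units; within the scatter). Compound 3 differs from compound 1 in the change (diethylamino in place of (tert-butyl)amino on an aromatic carbon), which made a 5.3-fold lower number from compound 1 to compound 3 (0.72 log units; beyond the scatter), leaving compound 3 with the lowest number of the three.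

Compound 4, `CCN(CC)c1c(C#N)c(F)c2c(N)nc(N)nc2c1F`, has not yet been tested in this assay. It differs from compound 3 by fluoro in place of chloro on an aromatic carbon. This is the same kind of change as that from compound 1 to compound 2, though not the same: in compound 1 the place is ortho to a (tert-butyl)amino group, whereas in compound 3 it is ortho to a diethylamino group.

Because the same kind of change gave a 1.1-fold higher number from compound 1 to compound 2 (0.06 log units; within the scatter), compound 4 is expected to show a 1.1-fold higher number from compound 3 to compound 4 (0.05 log units; within the scatter). The estimated value for compound 4 is 0.45 ug/mL, expected between 0.2 ug/mL and 1 ug/mL.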

Compound 4, half-maximal inhibitory concentration: 1 ug/mL
The estimate for compound 4 lay 2.2-fold (0.35 log units) below the measured number; low and high end bracket the measured number.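

In this assay, fluoro in place of chloro gave a 2.5-fold higher number from compound 3 to compound 4 (0.40 log units; beyond the scatter), and this step does not differ from its counterpart on the other core by more than the scatter of two such steps allows: the same change on two cores in this assay, a 1.1-fold higher number (0.06 log units; within the scatter) from compound 1 to compound 2 and a 2.5-fold higher number (0.40 log units; beyond the scatter) from compound 3 to compound 4, 2.2-fold (0.34 log units) apart, within the scatter of two such steps. Diethylamino in place of (tert-butyl)amino gave a 2.4-fold lower number from compound 2 to compound 4 (0.38 log units; beyond the scatter), and this step also agrees with its earlier counterpart: the same change on two cores in this assay, a 5.3-fold lower number (0.72 log units; beyond the scatter) from compound 1 to compound 3 and a 2.4-fold lower number (0.38 log units; beyond the scatter) from compound 2 to compound 4, 2.2-fold (0.34 log units) apart, within the scatter of two such steps. Each change therefore carried from one core to the other without a gap that can be told from scatter, but this rests on a single pair of steps per change and does not show that the steps are equal in size or that either change would carry to a further core.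

The compounds shown leave open how bromo or a hydrogen atom in place of the halogen would behave, and whether dimethylamino or a longer dialkylamino chain would follow the diethylamino step. From the compounds shown here alone, all four compounds keep the nitrile and the fluoro group, so what a primary amide or a carboxylic acid in place of the nitrile would do also remains open.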